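The compounds below may be only part of what the source reports. "The series", "measured", "known", "first", "only" and "open" are said of these compounds alone.

Measured in a functional assay on OVCAR-5 cells (Homo sapiens) for inhibition, read by sulforhodamine B assay, with a stated time of 48 h; on this read-out lower numbers stand for stronger inhibition of growth and higher numbers for weaker inhibition of growth:
- compound 1 `O=C(Nc1cccc(-n2cc(-c3ccncc3)c(-c3ccc(Cl)c(O)c3)n2)c1)Nc1cccc(C(F)(F)F)c1`: > 32500 nM (limit)
- compound 2 `COc1cc(-c2nn(-c3cccc(NC(=O)c4cccc(C(F)(F)F)c4)c3)cc2-c2ccncc2)ccc1Cl`: > 50000 nM (limit)
- compound 3 `O=C(Nc1cccc(-n2cc(-c3ccncc3)c(-c3ccc(Cl)c(O)c3)n2)c1)Nc1ccc(Cl)c(Cl)c1`: > 32500 nM (limit)

No exact number is available for any of these compounds. Compound 2 is reported only as a limit, > 50000 nM, which is the limit of > 50000 nM in this assay, at which 1 of the 3 values shown sits. Its place in the series therefore cannot be ranked against the other two compounds, which share (the limit of > 32500 nM in this assay, at which 2 of the 3 values shown sit).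

Compound 4 `COc1cc(-c2nn(-c3cccc(NC(=O)Nc4cccc(C(F)(F)F)c4)c3)cc2-c2ccncc2)ccc1Cl` is not yet measured. Its difference from compound 2 is (3-(trifluoromethyl)phenyl)amino in place of 3-(trifluoromethyl)phenyl on a carbonyl carbon, with (3-(trifluoromethyl)phenyl)amino in place of 3-(trifluoromethyl)phenyl on a carbonyl carbon.

Going by the values given here, the only measured step is a step that the two limits leave unreadable from compound 1 to compound 3. Among the compounds with values here, it concerns a different change and gives no usable size, so no measured step speaks directly to this replacement. The nearest evidence is compound 1, which carries (3-(trifluoromethyl)phenyl)amino on a carbonyl carbon. Compound 1 is itself a limit, > 32500 nM.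

On this basis, no step beyond the scatter is expected in this assay and no direction can be supported. The expected step is an at least 1.2-fold lower number from compound 2 to compound 4 (0.09 log units; that floor lies within the scatter), and a further limit is the likeliest report. The estimate for compound 4 is 40000 nM, with an expected range of 12000 nM to 80000 nM.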

Compound 4, concentration for total growth inhibition: 6450 nM
The estimate for compound 4 lay 6.2-fold (0.79 log units) above the measured number; measured number outside the range, below it.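

In this assay, going by these compounds alone, (3-(trifluoromethyl)phenyl)amino in place of 3-(trifluoromethyl)phenyl on a carbonyl carbon gives the first readable step, an at least 7.7-fold lower number from compound 2 to compound 4 (0.88 log units; beyond the scatter), so this position responds to a change that adds one nitrogen and one hydrogen-bond donor. With the (3-(trifluoromethyl)phenyl)amino group held constant, methyl in place of hydrogen on an oxygen on an aromatic ring gives an at least 5.0-fold lower number from compound 1 to compound 4 (0.70 log units; beyond the scatter), which shows that the oxygen substituent also matters and that the carbonyl-side change alone does not set the read-out. Both steps start from a limit and give only a minimum size, and for the first of them compound 2 is a limit: the limit of > 50000 nM in this assay, at which 1 of the 4 values shown sits.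

From the compounds shown here alone, compound 1 and compound 3 share a limit, so the step between them cannot be read, and the effect of 3,4-dichlorophenyl in the setting of compound 4 remains open: the limit of > 32500 nM in this assay, at which 2 of the 4 values shown sit. It also remains open whether the gain survives with an ethyl group on that oxygen, or with a carboxylic acid or an amine on the aromatic ring in place of trifluoromethyl.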